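Ring contraction on the amide nitrogen of compound 1

The compounds below may be only part of what the source reports. "The series", "measured", "known", "first", "only" and "open" are said of these compounds alone.

Compound 1, `CCN(CC)S(=O)(=O)c1ccc(S(=O)(=O)N2CCC[C@@H](C(=O)N[C@@H]3CCN(C(=O)OC(C)(C)C)C3)C2)cc1`, carries a 1-(tert-butoxycarbonyl)pyrrolidin-3-yl group on its amide nitrogen. In a functional assay on MIA PaCa-2 cells (Homo sapiens) for inhibition, read by MTT assay, with a stated time of 7 days (a lower number here means a stronger inhibitor, a higher number a weaker inhibitor), compound 1 gives 200 nM, the highest of the two numbers recorded so far. Its nearest neighbour is compound 2, `CCN(CC)S(=O)(=O)c1ccc(S(=O)(=O)N2CCC[C@@H](C(=O)NC3CCN(C(=O)OC(C)(C)C)CC3)C2)cc1`, which bears a six-membered saturated ring in the same position and in this assay gives 100 nM; the gap between these two values lies within the scatter, so the two compounds cannot be told apart on potency.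

The next compound, compound 3, `CCN(CC)S(=O)(=O)c1ccc(S(=O)(=O)N2CCC[C@@H](C(=O)NC3CN(C(=O)OC(C)(C)C)C3)C2)cc1`, takes the ring one size smaller: 1-(tert-butoxycarbonyl)azetidin-3-yl in place of 1-(tert-butoxycarbonyl)pyrrolidin-3-yl on an amide-type nitrogen. Among the compounds with values here, no measured pair in this set shows what such a ring contraction does, so the expectation rests on the observation that compound 1 and compound 2 sit within the scatter of each other despite their different ring sizes. Compound 3 is therefore expected to stay close to compound 1, with a step of a 1.5-fold higher number from compound 1 to compound 3 (0.18 log units; within the scatter) that need not exceed the scatter in either direction. The estimate for compound 3 in this assay is 300 nM, with a range from 100 nM to 900 nM.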

Compound 3, half-maximal inhibitory concentration: 200 nM
Compound 3: the middle estimate sits 1.5-fold (0.18 log units) above what was measured; the measured number falls inside the stated range.
By their numbers in this assay, from the lowest: compounds 2, 1 and 3 (each within the scatter of the next).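

In this assay, putting 1-(tert-butoxycarbonyl)azetidin-3-yl in place of 1-(tert-butoxycarbonyl)pyrrolidin-3-yl on an amide-type nitrogen gives no change at the digits printed from compound 1 to compound 3 (within the scatter), the first step read directly at this position. The change swaps a five-membered non-aromatic ring for a four-membered one and removes the defined stereocentre of the group that leaves, and neither shows up as a difference beyond the scatter in this read-out. Nothing available bears on why the number holds across this change.

As far as these compounds go, compound 1 and compound 3 both keep the tert-butoxycarbonyl group on the ring nitrogen, so it remains open how the read-out would respond if that group gave way to an acetyl group or to the free secondary amine. From the compounds shown here alone, it is equally open whether a saturated ring is needed on the amide-type nitrogen at all, since an open chain such as an isobutyl group or a flat ring such as phenyl would test this position in a way that ring contraction within the shared core of compound 1 cannot.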